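Adding a Butenyl Ether to Compound 3

A few compounds are considered here, and "the series" means these few. Any claim that something is new, unique, unknown or untested is made for them only; others in the source may bear on it.

In a functional assay on A549 cells (Homo sapiens) for inhibition, read by colorimetric assay and MTT assay, with a stated time of 72 h (on this read-out lower numbers stand for stronger inhibition and higher numbers for weaker inhibition), compound 1 `COc1ccc(C)cc1-c1cnc(OCCCCc2ccccc2)n1C` gives 40000 nM, and compound 2 `C=CCCOc1ncc(-c2ccccc2OC)n1C` gives 22000 nM; these two values lie within the usual scatter of each other. Compound 3 `Cn1c(-c2ccccc2O)cnc1S(=O)(=O)c1ccccc1` yields no number in this assay, only the limit > 100000 nM. Compound 3 thus stands at the limit of > 100000 nM in this assay, at which 1 of the 3 values shown sits. Compound 4 `C=CCCOc1ccccc1-c1cnc(S(=O)(=O)c2ccccc2)n1C` differs from it by but-3-en-1-yl in place of hydrogen on an oxygen on an aromatic ring. Among the measured compounds shown here, no measured step shows this change, but compound 2, which also carries a but-3-en-1-yl chain, reads 22000 nM. A moderate expected move towards stronger inhibition is an at least 2.8-fold lower number from compound 3 to compound 4 (0.45 log units; beyond the scatter). For compound 4 the estimated value is 35000 nM, with an expected range from 10000 nM to 100000 nM.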

Compound 4, half-maximal inhibitory concentration: 73000 nM
The estimate for compound 4 lay 2.1-fold (0.32 log units) below the measured number, within the range that was stated.
By their numbers in this assay, from the lowest: compounds 2, 1 and 4 (each within the scatter of the next, the first and the last beyond it). At a limit, above all of these: compound 3.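

Placing but-3-en-1-yl on the oxygen on the aromatic ring gives a measured number in this assay, with an at least 1.3-fold lower number from compound 3 to compound 4 (0.13 log units; that floor lies within the scatter). The true size of this step cannot be read, because compound 3 gives only a limit: the limit of > 100000 nM in this assay, at which 1 of the 4 values shown sits. The change is therefore not shown to move the number beyond the scatter.

The compounds shown leave open how a longer chain, or a chain ending in an amine, would read on this oxygen. They also leave open whether a saturated butyl chain would read like but-3-en-1-yl.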